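The source may hold more compounds than are shown below. What is called first, only, known or untested is meant among the compounds shown, and "the series" means these compounds.

For the measured compounds named here, the three compounds measured so far share one core and differ at two oxygens. Compound 1 `C=C1CC[C@@H]2[C@](C)(CO[Si](C(C)C)(C(C)C)C(C)C)[C@H](OC(C)=O)CC[C@@]2(C)[C@@H]1C/C=C1/C(=O)OC[C@H]1OC(C)=O` carries a large silyl group on the oxygen on a saturated carbon and an acetyl on the other; in a functional assay on Col2 cells (Homo sapiens) for cytotoxicity, read by sulforhodamine B assay (on this read-out higher numbers stand for an effect only at larger amounts of compound and lower numbers for an effect already at smaller amounts), compound 1 gives 13.6 uM. Compound 2 `C=C1CC[C@@H]2[C@](C)(CO)[C@H](OC(C)=O)CC[C@@]2(C)[C@@H]1C/C=C1/C(=O)OC[C@H]1O` has hydrogen at both places, and in this assay compound 2 gives 27.2 uM. Going by the values given here, compound 3 `C=C1CC[C@@H]2[C@](C)(CO)[C@H](OC(C)=O)CC[C@@]2(C)[C@@H]1C/C=C1/C(=O)OC[C@H]1OC(C)=O` has hydrogen at the first place and acetyl at the second; in this assay compound 3 gives 10.2 uM, the lowest of the three numbers, though the step of a 1.3-fold lower number from compound 1 to compound 3 (0.12 log units; within the scatter) is within the scatter, and only the step of a 2.7-fold lower number from compound 2 to compound 3 (0.43 log units; beyond the scatter) goes beyond it.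

Compound 4 `C=C1CC[C@@H]2[C@](C)(CO[Si](C)(C)C(C)(C)C)[C@H](OC(C)=O)CC[C@@]2(C)[C@@H]1C/C=C1/C(=O)OC[C@H]1OC(C)=O` differs from compound 3 by a group of 7 heavy atoms (6 carbon, 1 silicon; no ring) in place of a hydrogen atom, on an oxygen on a saturated carbon. Among the compounds with values here, the step that bears on it is the one from compound 1 to compound 3, where a larger silyl group left the same oxygen and gave a 1.3-fold lower number from compound 1 to compound 3 (0.12 log units; within the scatter), within the scatter. Putting a smaller silyl group back on that oxygen is therefore expected to move the number little, if at all, and no step beyond the scatter in this assay is expected in either direction, so that the expected step is a 1.2-fold higher number from compound 3 to compound 4 (0.07 log units; within the scatter). Compound 4 is accordingly estimated at 12 uM, with a range from 6 uM to 25 uM.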

Compound 4, concentration for half-maximal effect: 2.23 uM
Compound 4: middle estimate off by 5.4-fold (0.73 log units), on the high side; measured number outside the range, below it.
By their numbers in this assay, from the lowest: compound 4; then compounds 3, 1 and 2 (each within the scatter of the next, the first and the last beyond it).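

Before compound 4, the oxygen on a saturated carbon looked indifferent in this assay, since exchanging the larger silyl group for hydrogen stayed within the scatter (a 1.3-fold lower number from compound 1 to compound 3 (0.12 log units; within the scatter)). Compound 4 shows that this position can respond after all: the group of 7 heavy atoms (6 carbon, 1 silicon; no ring) in place of hydrogen gives a step beyond the scatter (a 4.6-fold lower number from compound 3 to compound 4 (0.66 log units; beyond the scatter)). The comparison of the two silyl-bearing compounds, which differ only in this group, shows that the identity of the group matters and not merely the presence of silicon on that oxygen (a 6.1-fold lower number from compound 1 to compound 4 (0.79 log units; beyond the scatter)), although nothing given here accounts for the gain in terms of a measured property.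

The compounds shown leave open whether the step is tied to silicon at all, since a benzyl group, a pivaloyl group or a longer chain on this oxygen would be needed to separate the silyl group from other groups of similar atom count, and a trimethylsilyl group would extend the silyl series downward. They also leave open whether the same group keeps its effect when the other oxygen carries hydrogen in place of acetyl, as it does in compound 2.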